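This account rests on a few compounds, and the source may have more. Where it says the series, first, only, none or still open, it means among the compounds named here.

Compounds measured in a functional assay on DU-145 cells (Homo sapiens) for antiproliferative activity, read by WST assay, with a stated time of 48 h, tested at 1 uM; on this read-out lower numbers stand for a weaker effect and higher numbers for a stronger effect at the one concentration tested:
- compound 1, `Cc1ccc2[nH]c(-n3[nH]c(C)c(Cc4ccccc4)c3=O)nc2c1`: 35%
- compound 2, `Cc1[nH]n(-c2nc3cc(C(F)(F)F)ccc3[nH]2)c(=O)c1Cc1ccccc1`: 78%

Compound 2 stands highest of the two numbers; its nearest neighbour is compound 1, which in this assay gives 35%, and the step of a number 43 percentage points higher from compound 1 to compound 2 (beyond the scatter) is beyond the scatter.

Compound 3, `Cc1[nH]n(-c2nc3cc(-c4ccc(Cl)cc4)ccc3[nH]2)c(=O)c1Cc1ccccc1`, is not yet measured. It differs from compound 2 in one place: 4-chlorophenyl in place of trifluoromethyl on an aromatic carbon.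

Among the measured compounds shown here, only one measured step bears on this position, a number 43 percentage points higher from compound 1 to compound 2 (beyond the scatter), and it is large. For the measured compounds named here, that step exchanged methyl for trifluoromethyl; no measured pair shows what a 4-chlorophenyl at this position does, so the direction of the step from compound 2 is open. The size of the earlier step at this position suggests it is sensitive to what stands there. With compound 2 already high, a further gain is bounded, while a loss of part of the gain seen in a number 43 percentage points higher from compound 1 to compound 2 (beyond the scatter) is plausible. The expectation for compound 3 is therefore a modest step downward, a number 13 percentage points lower from compound 2 to compound 3 (beyond the scatter), with wide uncertainty. The estimate for compound 3 in this assay is 65%, range 35% to 90%.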

Compound 3, a percentage reported as inhibition, at one concentration (the size of the read-out at that concentration, not a potency): 70%
For compound 3 the middle estimate is 5 percentage points below the measured one; measured number inside the range.
By their numbers in this assay, from the lowest: compound 1; then compounds 3 and 2 (each within the scatter of the next).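

In this assay, this aromatic carbon accepts a 4-chlorophenyl, a group with its own six-membered aromatic ring, about as well as a trifluoromethyl, which has no ring: a number 8 percentage points lower from compound 2 to compound 3 (within the scatter). Measured against the methyl, the 4-chlorophenyl gives a number 35 percentage points higher from compound 1 to compound 3 (beyond the scatter), so the large gain first seen with trifluoromethyl is not confined to that one group, at least across these three compounds. Nothing at hand bears on why these two different groups give such similar readings.

From the compounds shown here alone, what an amine, a carboxylic acid or a plain hydrogen at this position would give remains open, as does the effect of a longer alkyl chain in place of the methyl. Also open, going by these compounds, is whether compound 2 and compound 3 stay alike at other concentrations; a reading at one concentration is not a potency.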